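Dropping the Sulfonylphenyl Arm: Expected Microsomal Half-life

The compounds below may be only part of what the source reports. "The series", "measured", "known", "first", "only" and "open" are said of these compounds alone.

Compound 1 `CC(C)S(=O)(=O)c1ccc(-c2c[nH]c3c(=O)n(Cc4cc(F)ccc4C#N)c(N4CCC[C@@H](N)C4)nc23)cc1` is the starting point. In an ADME assay on microsomes from liver (Rattus norvegicus) for metabolic stability, read by LC-MS, tested at 1 mM (a lower number here means that the compound disappears faster, a higher number that the compound lasts longer), compound 1 gives > 3.33 h, which is a limit of the assay rather than a number (the limit of > 3.33 h in this assay, at which 1 of the 3 values shown sits). Compound 2 `N#Cc1ccc(F)cc1Cn1c(N2CCC[C@@H](N)C2)nc2c(F)c[nH]c2c1=O` gives 0.838 h in this assay, and compound 3 `N#Cc1ccc(F)cc1Cn1c(N2CCC[C@@H](N)C2)nc2c(-c3ccsc3)c[nH]c2c1=O` gives 0.783 h. The measured steps are an at least 3.9-fold lower number from compound 1 to compound 2 (0.59 log units; beyond the scatter) and an at least 4.2-fold lower number from compound 1 to compound 3 (0.62 log units; beyond the scatter), while a 1.1-fold lower number from compound 2 to compound 3 (0.03 log units; within the scatter). Compound 4 `N#Cc1ccc(F)cc1Cn1c(N2CCC[C@@H](N)C2)nc2cc[nH]c2c1=O` differs from compound 1 as follows: hydrogen in place of 4-(isopropylsulfonyl)phenyl on an aromatic carbon. Both measured exchanges of the 4-(isopropylsulfonyl)phenyl group for a smaller group gave a clearly lower number, so a drop of similar size is expected for the step to hydrogen, an at least 4.1-fold lower number from compound 1 to compound 4 (0.61 log units; beyond the scatter). Compound 4 is accordingly expected to give 0.8 h in this assay, with a likely range from 0.4 h to 1.6 h.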

Compound 4, half-life: > 1 h
Compound 4 gave a limit, no number; the forecaster's own chance of this, stated with the estimate: 5%; middle value at least 1.2-fold (0.09 log units) away from the limit.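

Compound 4, with hydrogen on this aromatic carbon of the five-membered ring, gives a limit of the assay rather than a number: the limit of > 1 h in this assay, at which 1 of the 4 values shown sits. The new steps are an at least 1.2-fold higher number from compound 3 to compound 4 (0.10 log units; that floor lies within the scatter) and an at least 1.1-fold higher number from compound 2 to compound 4 (0.07 log units; that floor lies within the scatter), so the true gaps may be small or large. The step between compound 1 and compound 4 cannot be read because compound 1 also stands at a limit: the limit of > 3.33 h in this assay, at which 1 of the 4 values shown sits.

From the compounds shown here alone, whether the 4-(isopropylsulfonyl)phenyl group offers any gain over hydrogen remains open. So does how an amine or a methoxy group on this carbon would behave.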